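The compounds below may be only part of what the source reports. "The series", "measured", "known", "first", "only" and "open" are said of these compounds alone.

Measured in an assay for inhibition of Dihydrofolate reductase (Bos taurus), at pH 6.25; on this read-out lower numbers stand for lower potency and higher numbers for higher potency (the scale is a negative logarithm):
compound 1 `CC1(C)N=C(N)N=C(N)N1c1ccccc1F`, 4.86
compound 2 `CC1(C)N=C(N)N=C(N)N1c1ccccc1I`, 3.43
compound 3 `CC1(C)N=C(N)N=C(N)N1c1ccccc1S`, 7.2

Compound 3 holds the highest of the three numbers; compound 1 sits nearest, with a number 2.34 log units higher from compound 1 to compound 3 (beyond the scatter) separating them, and compound 2 sits furthest, with a number 3.77 log units higher from compound 2 to compound 3 (beyond the scatter) separating them. Both of these steps put sulfanyl in place of a halogen and both are large gains, so the sulfanyl group accounts for most of the spread in this small set. Between the two halogens themselves the difference is also beyond the scatter, as a number 1.43 log units lower from compound 1 to compound 2 (beyond the scatter) shows, so a group other than sulfanyl at this carbon can land anywhere across a wide band of low numbers.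

Compound 4 `CC1(C)N=C(N)N=C(N)N1c1ccccc1C(F)(F)F` is the next member. It differs from compound 3 by trifluoromethyl in place of sulfanyl on an aromatic carbon. For the measured compounds named here, the two steps that bear on it, the ones that introduce sulfanyl, both run upward and large; the step to compound 4 reverses that and removes the sulfanyl group, so a large drop in this assay is expected, of the order of the sulfanyl steps, though no measured pair contains trifluoromethyl and the landing point within the halogen band is uncertain. Compound 4 is therefore expected to come in around 4.5, with a range of 3.4 to 5.8, which means an expected step of a number 2.70 log units lower from compound 3 to compound 4 (beyond the scatter).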

Compound 4, logarithm of the reciprocal of the active concentration, log(1/C): 3.15
The estimate for compound 4 lay 1.35 log units above the measured number, outside the stated range (below it).
By their numbers in this assay, from the lowest: compounds 4 and 2 (each within the scatter of the next); then compound 1; then compound 3.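

In this assay trifluoromethyl in place of sulfanyl gives a number 4.05 log units lower from compound 3 to compound 4 (beyond the scatter) and so the high number of compound 3 now stands against a third group that is not sulfanyl, and no longer against halogens alone. The new group does not simply join the halogens at one level: a number 0.28 log units lower from compound 2 to compound 4 (within the scatter) leaves it not separable from the iodo compound, while a number 1.71 log units lower from compound 1 to compound 4 (beyond the scatter) places it clearly under the fluoro compound. Across these four compounds sulfanyl alone reaches the high number and fluoro alone stands clear of the low pair, and the step to compound 4 also exchanges a group counted with 1 hydrogen-bond donor and 1 hydrogen-bond acceptor for one counted with 0 of each, which here is a description and not an explanation.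

On these data alone, whether the high number belongs to sulfanyl specifically, or would also be reached at this carbon by a hydroxyl group, an amine or a methylthio group, stays open, as does where a plain methyl group would fall. Nothing given here bears on why the loss from sulfanyl is so large.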